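This account rests on a few compounds, and the source may have more. Where it says the series, first, only, none or still open, it means among the compounds named here.

Measured in a functional assay on A549 cells (Homo sapiens) for antiproliferative activity, read by MTT assay, with a stated time of 48 h; on this read-out lower numbers stand for stronger inhibition and higher numbers for weaker inhibition:
- compound 1 `Cn1cc(C2=C(c3nn(CCCn4cncn4)c4ncccc34)C(=O)NC2=O)c2ccccc21`: > 100000 nM, a limit
- compound 2 `Cn1cc(C2=C(c3nn(CCCn4cncn4)c4ncccc34)C(=O)N(c3ccccc3)C2=O)c2ccccc21`: > 100000 nM, a limit
- compound 3 `Cn1cc(C2=C(c3nn(CCCN4CCCCC4)c4ncccc34)C(=O)N(c3ccc(Cl)cc3)C2=O)c2ccccc21`: 28700 nM

Compound 2 has no exact number and stands at the limit of > 100000 nM in this assay, at which 2 of the 3 values shown sit.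

Compound 4 `Cn1cc(C2=C(c3nn(CCCn4ccnc4)c4ncccc34)C(=O)N(c3ccccc3)C2=O)c2ccccc21` changes one group of compound 2: 1H-imidazol-1-yl in place of 1H-1,2,4-triazol-1-yl on a saturated chain carbon, three bonds along the chain from an aromatic nitrogen. That is, 1H-imidazol-1-yl replaces 1H-1,2,4-triazol-1-yl on a saturated chain carbon, three bonds along the chain from an aromatic nitrogen.

Little measured evidence bears on this swap. Within the data shown here, the only step available is a step that the two limits leave unreadable from compound 1 to compound 2, and it concerns a different place, on an amide-type nitrogen in a ring. Among the measured compounds shown here, compound 3 gives a real number, 28700 nM, but it differs from compound 2 in more than one place, so it yields no clean step.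

The expectation therefore rests on compound 2 and its value of > 100000 nM, which is a limit. The expected change is a number no higher from compound 2 to compound 4 (the limit leaves the size open), with no step beyond the scatter. For compound 4 the estimate is 100000 nM, with an expected range of 35000 nM to 200000 nM.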

Compound 4, half-maximal inhibitory concentration: 1560 nM
Compound 4: middle estimate off by 64-fold (1.81 log units), on the high side, outside the stated range (below it).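

In this assay, 1H-imidazol-1-yl in place of 1H-1,2,4-triazol-1-yl on a saturated chain carbon, three bonds along the chain from an aromatic nitrogen, gives an at least 64-fold lower number from compound 2 to compound 4 (1.80 log units; beyond the scatter). Among these compounds, this is the first readable step, as the earlier step at the amide-type nitrogen in a ring cannot be read, and it shows that the end of this chain responds strongly to exchanging one five-membered aromatic ring for another with one hetero atom fewer. Compound 2 has only a limit, so the size printed for the step is a minimum: the limit of > 100000 nM in this assay, at which 2 of the 4 values shown sit.

Going by these compounds, what a longer chain or a dimethylamino group would do at this place remains open. So does whether the same swap would lower the number with the amide hydrogen of compound 1 or with another group on that nitrogen.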